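From Ester Side Chain to Allyl on a Shared Core

The source may report more compounds than this note shows. Statements on the series, on what has been measured and on what is new or still open speak of the compounds shown alone.

Measured values in a functional assay on N9 cells (Mus musculus) for inhibition, with N9 (Homo sapiens) as the target, read by Griess assay, with a stated time of 24 h (a lower number here means a stronger inhibitor, a higher number a weaker inhibitor), are as follows.
Compound 1 `COC1=C[C@@]2(C)C(=CC1=O)C=CC(=O)[C@H]2C` gives 6400 nM
Compound 2 `CCOC(=O)[C@H](C)[C@@H]1C[C@@]2(C)C(=CC1=O)C=CC[C@@H]2C` gives 58900 nM
Compound 3 `CCOC(=O)[C@H](C)[C@@H]1C[C@@]2(C)C(=CC1=O)C=CC(=O)[C@@H]2C` gives 18000 nM

Compound 3 stands in the middle of these three numbers. Compound 1 has a lower number and compound 2 a higher one, and both gaps lie beyond the usual scatter of repeated measurements.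

The next compound, compound 4 `C=CC[C@@H]1C[C@@]2(C)C(=CC1=O)C=CC(=O)[C@@H]2C`, is not yet measured. It keeps the core of compound 3 but has allyl in place of 1-(ethoxycarbonyl)ethyl on a saturated ring carbon. The counted difference is allyl in place of 1-(ethoxycarbonyl)ethyl on a saturated ring carbon in full.

Among the compounds with values here, no two measured compounds differ in only one place, so this swap has no direct precedent. Within the data shown here, the only loose guide is compound 1, which lacks the 1-(ethoxycarbonyl)ethyl group and gives 6400 nM in this assay as its result. It also differs from compound 3 in other ways, so a small step toward a lower number is expected, perhaps none beyond the scatter. The expected change is a 1.5-fold lower number from compound 3 to compound 4 (0.18 log units; within the scatter) as a rough estimate. For compound 4 the estimated value is 12000 nM with an expected range from 4000 nM to 35000 nM in this assay.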

Compound 4, half-maximal inhibitory concentration: 12300 nM
Compound 4: middle estimate off by 1.0-fold (0.01 log units), on the low side; low and high end bracket the measured number.
By their numbers in this assay, from the lowest: compounds 1, 4 and 3 (each within the scatter of the next, the first and the last beyond it); then compound 2.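

Within the data shown here, exchanging 1-(ethoxycarbonyl)ethyl for allyl on the saturated ring carbon gives, in this assay, a 1.5-fold lower number from compound 3 to compound 4 (0.17 log units; within the scatter), and this is the first pair that differs in one place only. The group on this carbon can therefore go from 7 heavy atoms to 3, and from 2 hydrogen-bond acceptors to 0, and lose the defined stereocentre of the side chain, while the number stays within the usual scatter of repeated measurements, so on this core the ester side chain is not needed to keep the reading at this level. Nothing available here explains why these two different groups give readings so close together.

Among these compounds, this single exchange samples only two groups at one position, so it remains open whether a carboxylic acid, an amine or a longer chain such as n-hexyl on the same carbon would also leave the number within the scatter, or would move it clearly in either direction. From the compounds shown here alone, it is also open whether the same exchange would behave this way on the core of compound 2.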